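Notes on the side chain: compound 3 to compound 4

This account rests on a few compounds, and the source may have more. Where it says the series, first, only, none or still open, it means among the compounds named here.

compound 1 `COc1ccc(CN(C(=O)CSC2=CN=NC2C)c2cc(OC)c(OC)c(OC)c2)cc1`: 45000 nM
compound 2 `COc1ccc(CN(C(=O)CSc2nc3ccc(OC)cc3s2)c2cc(OC)c(OC)c(OC)c2)cc1`: 20200 nM
compound 3 `COc1ccc(CN(C(=O)CCCSc2nc3ccccc3o2)c2cc(OC)c(OC)c(OC)c2)cc1`: 32700 nM

All three values come from a functional assay on PC-3 cells (Homo sapiens) for antiproliferative activity, read by MTT assay, with a stated time of 48 h; on this read-out higher numbers stand for weaker inhibition and lower numbers for stronger inhibition. Compound 3, at 32700 nM, lies within the scatter of both other compounds, as shown by a 1.4-fold lower number from compound 1 to compound 3 (0.14 log units; within the scatter) and a 1.6-fold higher number from compound 2 to compound 3 (0.21 log units; within the scatter). Only a 2.2-fold lower number from compound 1 to compound 2 (0.35 log units; beyond the scatter) goes beyond the scatter, and it is modest.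

Still unmeasured is compound 4 `COc1ccc(CN(C(=O)CSc2nnnn2C)c2cc(OC)c(OC)c(OC)c2)cc1`. The change is (1-methyl-1H-tetrazol-5-yl)sulfanyl in place of 2-((1,3-benzoxazol-2-yl)sulfanyl)ethyl on a saturated chain carbon bound to a carbonyl carbon. Thus (1-methyl-1H-tetrazol-5-yl)sulfanyl stands in place of 2-((1,3-benzoxazol-2-yl)sulfanyl)ethyl, on a saturated chain carbon bound to a carbonyl carbon, and the six-membered aromatic ring of carbon only is lost.

For the measured compounds named here, no measured compound carries this tetrazolyl group, so the evidence is indirect. Compound 1 is the closest case, with one five-membered ring and no six-membered ring in its group. Its steps to the two-ring groups are small: a 2.2-fold lower number from compound 1 to compound 2 (0.35 log units; beyond the scatter) and a 1.4-fold lower number from compound 1 to compound 3 (0.14 log units; within the scatter). Compound 4 is therefore expected to sit near compound 1, at 45000 nM. The expected move in this assay is small, towards a higher number, and stays within the scatter: a 1.2-fold higher number from compound 3 to compound 4 (0.09 log units; within the scatter). For compound 4 the estimated value is 40000 nM, with an expected range from 17000 nM to 90000 nM.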

Compound 4, half-maximal inhibitory concentration: 10500 nM
Compound 4: middle estimate off by 3.8-fold (0.58 log units), on the high side; measured number below the stated range.
By their numbers in this assay, from the lowest: compounds 4, 2, 3 and 1 (each within the scatter of the next, the first and the last beyond it).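

In this assay, a single five-membered aromatic ring is enough at this place: (1-methyl-1H-tetrazol-5-yl)sulfanyl on a saturated chain carbon bound to a carbonyl carbon gives a modest gain over the larger group (a 3.1-fold lower number from compound 3 to compound 4 (0.49 log units; beyond the scatter)), even though the six-membered aromatic ring of carbon only is lost. On the sulfur, 1-methyl-1H-tetrazol-5-yl and 6-methoxy-1,3-benzothiazol-2-yl cannot be told apart (a 1.9-fold lower number from compound 2 to compound 4 (0.28 log units; within the scatter)), so among these compounds the two-ring groups bring no advantage. Heavy-atom count alone does not set the value, since the groups on the sulfur in compound 1 and compound 4 both have 6 heavy atoms yet differ in composition and ring type and give a modest separation (a 4.3-fold lower number from compound 1 to compound 4 (0.63 log units; beyond the scatter)).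

Nothing among the available data accounts for these differences. As far as these compounds go, the step from compound 3 also leaves the chain and ring changes unseparated, which a 2-((1-methyl-1H-tetrazol-5-yl)sulfanyl)ethyl group would address, and it remains open whether a carboxylic acid or an amine could replace the methyl on the tetrazole ring.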